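A Second Chloro on the Phenyl of Compound 1

The compounds below may be only part of what the source reports. "The series", "measured", "known", "first", "only" and "open" are said of these compounds alone.

Of the compounds shown here, three built on one shared core have been measured in a functional assay on HepG2 cells (Homo sapiens) for antiproliferative activity, read by MTT assay, with a stated time of 48 h; a lower number here means a stronger inhibitor, a higher number a weaker inhibitor. Compound 1 `O=C(Nc1cccc(Cl)c1)Nc1nnc(Sc2ncnc3scc(-c4ccncc4)c23)s1` gives 22900 nM. Compound 2 `O=C(Nc1cccc(C(F)(F)F)c1)Nc1nnc(Sc2ncnc3scc(-c4ccncc4)c23)s1` gives 15300 nM, and compound 3 `O=C(Nc1ccc(F)cc1)Nc1nnc(Sc2ncnc3scc(-c4ccncc4)c23)s1` gives 31700 nM. On these numbers compound 1 stands second highest of the three: there is a 1.5-fold lower number from compound 1 to compound 2 (0.18 log units; within the scatter), and there is a 1.4-fold higher number from compound 1 to compound 3 (0.14 log units; within the scatter), both within the scatter. Within the data shown here, the only step beyond the scatter is a modest one, a 2.1-fold higher number from compound 2 to compound 3 (0.32 log units; beyond the scatter).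

Compound 4 `O=C(Nc1ccc(Cl)c(Cl)c1)Nc1nnc(Sc2ncnc3scc(-c4ccncc4)c23)s1` differs from compound 1 by a single change: chloro in place of hydrogen on an aromatic carbon. Among the measured compounds shown here, no measured step adds a group while the rest of the phenyl is kept, so the steps that bear on it are a 1.5-fold lower number from compound 1 to compound 2 (0.18 log units; within the scatter) and a 1.4-fold higher number from compound 1 to compound 3 (0.14 log units; within the scatter), both exchanges of one substituted phenyl for another, and both small. The expected step in this assay is therefore small as well, if anything toward a lower number, and not beyond the scatter. Compound 4 is expected to give 18000 nM, with a range from 8000 nM to 40000 nM. That expectation amounts to a 1.3-fold lower number from compound 1 to compound 4 (0.10 log units; within the scatter).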

Compound 4, half-maximal inhibitory concentration: 61900 nM
The estimate for compound 4 lay 3.4-fold (0.54 log units) below the measured number; measured number above the stated range.
By their numbers in this assay, from the lowest: compounds 2, 1, 3 and 4 (each within the scatter of the next, the first and the last beyond it).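

In this assay, the added chloro, ortho to a chloro group and para to a large group, is the first change shown that adds to the phenyl while keeping the rest of it, and it gives a 2.7-fold higher number from compound 1 to compound 4 (0.43 log units; beyond the scatter), so this aromatic carbon does not tolerate every added atom without a measurable step. The 3,4-dichlorophenyl group also gives the largest step among the four compounds when set against the 3-(trifluoromethyl)phenyl group, with a 4.0-fold higher number from compound 2 to compound 4 (0.61 log units; beyond the scatter), while against the 4-fluorophenyl group there is a 2.0-fold higher number from compound 3 to compound 4 (0.29 log units; within the scatter), so compound 4 cannot be separated from compound 3 on these numbers. Nothing measured here explains why the added chloro gives this step.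

The compounds shown leave open whether the step belongs to chloro itself or would follow any group on this carbon, a question that a methoxy or an amino group in its place could help settle. They also leave open whether the step depends on the chloro group already on the ring, which a 4-chlorophenyl group on the same core would test.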